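The source may hold more compounds than are shown below. What is called first, only, known or untested is meant among the compounds shown, and "the series" means these compounds.

Measured compounds in a functional assay on DU-145 cells (Homo sapiens) for cytotoxicity, read by MTT assay, with a stated time of 72 h; on this read-out lower numbers stand for stronger inhibition and higher numbers for weaker inhibition:
- compound 1 `COc1ccc(C(=O)c2cc(OC)c(OC)c(OC)c2)cc1NC(=O)/C=C/c1ccc(F)cc1` gives 3900 nM
- compound 2 `COc1cc(C(=O)c2cc(OC)c(OC)c(OC)c2)cc(NC(=O)/C=C/c2cc(OC)c(OC)c(OC)c2)c1OC` gives 6600 nM
- compound 3 `COc1ccc(/C=C/C(=O)Nc2cc(C(=O)c3cc(OC)c(OC)c(OC)c3)cc(OC)c2OC)cc1N` gives 12700 nM

Compound 3 stands highest of the three numbers in this assay; compound 2 sits nearest, within the scatter, and compound 1 sits furthest, beyond the scatter. Within the data shown here, the one step recorded on the shared core, a 1.9-fold higher number from compound 2 to compound 3 (0.28 log units; within the scatter), replaced the trimethoxyphenyl by the 3-amino-4-methoxyphenyl and moved the number only within the scatter.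

Compound 4 `COc1cc(C(=O)c2cc(OC)c(OC)c(OC)c2)cc(NC(=O)/C=C/c2ccc(F)cc2)c1OC` is not yet measured. It differs from compound 3 by 4-fluorophenyl in place of 3-amino-4-methoxyphenyl on a double-bonded chain carbon bound to a double-bonded chain carbon. Among the measured compounds shown here, no measured step carries exactly this change. Compound 1 carries the same 4-fluorophenyl on a different core and gives 3900 nM, the lowest of the three numbers, while compound 3 with the 3-amino-4-methoxyphenyl gives 12700 nM; the two differ beyond the scatter. On that showing a modest downward step is expected, a 2.3-fold lower number from compound 3 to compound 4 (0.36 log units; beyond the scatter), though the core change between compound 1 and compound 3 is unaccounted for. For compound 4 the expected value in this assay is 5500 nM, with a range from 2500 nM to 12000 nM.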

Compound 4, half-maximal inhibitory concentration: 6700 nM
Beside the measured number, compound 4's estimate is 1.2-fold (0.09 log units) below it, within the range that was stated.
By their numbers in this assay, from the lowest: compounds 1, 2, 4 and 3 (each within the scatter of the next, the first and the last beyond it).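

On the shared core in (this assay), the place on a double-bonded chain carbon bound to a double-bonded chain carbon now holds three aryl groups, and both exchanges to 4-fluorophenyl stay within the scatter, from 3-amino-4-methoxyphenyl (a 1.9-fold lower number from compound 3 to compound 4 (0.28 log units; within the scatter)) and from 3,4,5-trimethoxyphenyl (a 1.0-fold higher number from compound 2 to compound 4 (0.01 log units; within the scatter)). The series also gains its first reading of methoxy in place of hydrogen on an aromatic carbon, which likewise stays within the scatter (a 1.7-fold higher number from compound 1 to compound 4 (0.24 log units; within the scatter)). No supporting measurement bears on these results.

Open, from the compounds shown here alone, is whether any group at this place moves the number beyond the scatter, for example a carboxylic acid or a nitrile on the phenyl ring. Also open, going by these compounds, is whether the flat response holds outside this one cell line.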